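Little change expected from a new aromatic group

The source may report more compounds than this note shows. Statements on the series, on what has been measured and on what is new or still open speak of the compounds shown alone.

In a functional assay on OVCAR-3 cells (Homo sapiens) for cytotoxicity, read by sulforhodamine B assay (on this read-out higher numbers stand for weaker inhibition of growth and lower numbers for stronger inhibition of growth), compound 1 (`CC1=CC[C@@H]([C@@](C)(O)CCCC(C)(C)NC(=S)N/N=C\c2ccccc2)CC1`) gives 12900 nM and compound 2 (`CC1=CC[C@@H]([C@@](C)(O)CCCC(C)(C)NC(=S)N/N=C\c2ccccc2[N+](=O)[O-])CC1`) gives 16200 nM, so compound 2 stands level with compound 1 within the scatter. Compound 3 (`CC1=CC[C@@H]([C@@](C)(O)CCCC(C)(C)NC(=S)N/N=C\c2ccc(Cl)cc2)CC1`) differs from compound 2 by 4-chlorophenyl in place of 2-nitrophenyl on a carbon with a double bond to nitrogen. For the measured compounds named here, no compound carrying chlorine has been measured yet. Going by the values given here, the only measured step on this aromatic ring is the nitro in place of hydrogen, a 1.3-fold higher number from compound 1 to compound 2 (0.10 log units; within the scatter), so no step beyond the scatter is expected in this assay. The expected step of a 1.2-fold lower number from compound 2 to compound 3 (0.06 log units; within the scatter) stays within the scatter. Compound 3 is estimated at 14000 nM, with an expected range of 7000 nM to 28000 nM.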

Compound 3, concentration for total growth inhibition: 12800 nM
The estimate for compound 3 lay 1.1-fold (0.04 log units) above the measured number, within the range that was stated.
By their numbers in this assay, from the lowest: compounds 3, 1 and 2 (each within the scatter of the next).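

In this assay, chlorine joins nitro as a second group that this aromatic ring carries without a step beyond the scatter: chloro in place of hydrogen gives a 1.0-fold lower number from compound 1 to compound 3 (0.00 log units; within the scatter), and 4-chlorophenyl in place of 2-nitrophenyl gives a 1.3-fold lower number from compound 2 to compound 3 (0.10 log units; within the scatter). The plain phenyl, 2-nitrophenyl and 4-chlorophenyl compounds therefore read alike on this measure. Nothing available offers a reason for this sameness. As far as these compounds go, whether an amine or a carboxylic acid on this ring would move the number remains open. So does the outcome of replacing the ring with a plain alkyl chain.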